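Adding a Second Fluorine to the Anilide Ring

The source may report more compounds than this note shows. Statements on the series, on what has been measured and on what is new or still open speak of the compounds shown alone.

Compound 1 `O=C(CN1CCN(c2nnc(Cc3ccncc3)c3ccccc23)CC1)Nc1cccc(F)c1` is the starting point here. Within the data shown here, in a functional assay on HT-29 cells (Homo sapiens) for cytotoxicity, read by MTT assay, with a stated time of 72 h (on this read-out lower numbers stand for stronger inhibition and higher numbers for weaker inhibition), compound 1 gives 6130 nM, the lowest of the two numbers measured so far. Among the measured compounds shown here, its only measured neighbour is compound 2 `O=C(CN1CCN(c2nnc(Cc3ccccc3)c3ccccc23)CC1)Nc1cccc(F)c1`, which in this assay gives 95000 nM; that single step, a 15-fold higher number from compound 1 to compound 2 (1.19 log units; beyond the scatter), comes from putting phenyl in place of pyridin-4-yl on a saturated chain carbon bound to an aromatic carbon.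

Compound 3 `O=C(CN1CCN(c2nnc(Cc3ccncc3)c3ccccc23)CC1)Nc1ccc(F)c(F)c1` has not yet been measured. It differs from compound 1 in one place: fluoro in place of hydrogen on an aromatic carbon. The change sits on the fluorophenyl amide end of the molecule, far from the pyridinyl side where the step from compound 1 to compound 2 was measured, so that step says little about what to expect. For the measured compounds named here, with no measured step touching this ring, a small movement in this assay that stays within the scatter is the most reasonable expectation, a 1.2-fold lower number from compound 1 to compound 3 (0.09 log units; within the scatter). Compound 3 is therefore estimated at 5000 nM in this assay, with a likely range from 1800 nM to 15000 nM.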

Compound 3, half-maximal inhibitory concentration: 2320 nM
For compound 3 the middle estimate is 2.2-fold (0.33 log units) above the measured one, within the range that was stated.
By their numbers in this assay, from the lowest: compound 3; then compound 1; then compound 2.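

Among these compounds, this is the first measured change on the anilide ring, and in this assay the step to the 3,4-difluorophenyl amide gives a 2.6-fold lower number from compound 1 to compound 3 (0.42 log units; beyond the scatter) and so lies beyond the usual scatter. It shows that this end of the molecule can also move the number: one added fluoro, ortho to a fluoro group and para to a large group, is enough to produce a modest change, while the step at the other end of the molecule, a 15-fold higher number from compound 1 to compound 2 (1.19 log units; beyond the scatter) is large by comparison. No supporting measurement is available to explain why the added fluoro goes with a lower number in this cell assay.

The compounds shown leave open whether a chloro group, a methoxy group or an amine at this same ring carbon would shift the number in the same direction, or by a similar amount. Also open, from the compounds shown here alone, is whether the same added fluoro would lower the number on compound 2, where phenyl stands in place of pyridin-4-yl.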